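The compounds below may be only part of what the source reports. "The series", "measured", "known", "first", "only" and "open" are said of these compounds alone.

Working notes on the series.

Compound 1 `COc1cc(CC(O)c2ccc(-c3cccc(C#N)c3)cc2)c([N+](=O)[O-])cc1OC` and compound 2 `COc1cc(CC(O)c2ccc(-c3ccccc3F)cc2)c([N+](=O)[O-])cc1OC` share one core and differ only in the aryl group on the aromatic carbon. In an ADME assay on HeLa Rh cells (Homo sapiens) for cytotoxicity, read by microscopy (a higher number here means that more compound is tolerated, a lower number that less compound is tolerated), compound 1 gives 5200 nM. In this assay compound 2 gives 5000 nM. For the measured compounds named here, the single measured step, a 1.0-fold lower number from compound 1 to compound 2 (0.02 log units; within the scatter), is within the scatter, so compound 2 stands with the lowest of the two numbers, but its gap to compound 1 carries no weight.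

The next compound, compound 3 `COc1cc(CC(O)c2ccc(-c3ccncc3)cc2)c([N+](=O)[O-])cc1OC`, follows from compound 2 by the change (pyridin-4-yl in place of 2-fluorophenyl on an aromatic carbon). Going by the values given here, the one step that bears on this, a 1.0-fold lower number from compound 1 to compound 2 (0.02 log units; within the scatter), also exchanged the aryl group on that aromatic carbon and gave no movement beyond the scatter. Among the compounds with values here, no measured pair exchanges a carbocyclic aryl group for a pyridin-4-yl group, so the expectation rests on that single step alone. The step from compound 2 to compound 3 is therefore expected to be small, no change at the digits printed from compound 2 to compound 3 (within the scatter), in no clear direction. For compound 3 the estimate in this assay is 5000 nM, with a range from 2500 nM to 10000 nM.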

Compound 3, half-maximal cytotoxic concentration: > 263000 nM
Compound 3 was reported as a limit (the forecaster's own chance of this, stated with the estimate: 5%); at least 52-fold (1.72 log units) between middle value and limit.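

In this assay this aromatic carbon no longer looks indifferent to the aryl group it carries, since the exchange for pyridin-4-yl gives large steps: an at least 52-fold higher number from compound 2 to compound 3 (1.72 log units; beyond the scatter), and an at least 50-fold higher number from compound 1 to compound 3 (1.70 log units; beyond the scatter). Compound 3 is reported as a limit and not as a number: the limit of > 263000 nM in this assay, at which 1 of the 3 values shown sits. For the compounds shown here, both steps therefore fix only a minimum size, and pyridin-4-yl is the only one of the three groups with a hetero atom in its aromatic ring, an association among three compounds that assigns no cause.

On these data alone, it remains open whether the position of the ring nitrogen matters, which pyridin-3-yl or pyridin-2-yl on the same carbon would address, and whether a pyrimidinyl ring would go with a similar number. As far as these compounds go, it also remains open whether a phenyl ring carrying an amine or a carboxylic acid would stay with compound 1 and compound 2 or move with compound 3, and how far the number for compound 3 lies beyond its limit.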